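A few compounds are considered here, and "the series" means these few. Any claim that something is new, unique, unknown or untested is made for them only; others in the source may bear on it.

The compounds share one core. It appears in compound 1 `Cc1cc(O)c(C(=O)/C=C/c2cccc(Br)c2)c(=O)o1`, in compound 2 `Cc1cc(O)c(C(=O)/C=C/c2ccc(C(F)(F)F)cc2)c(=O)o1`, in compound 3 `COc1cc(/C=C/C(=O)c2c(O)cc(C)oc2=O)ccc1O` and in the not yet measured compound 4 `COc1ccc(/C=C/C(=O)c2c(O)cc(C)oc2=O)cc1`. Among the compounds with values here, the three measured members were tested in an ADME assay on HEK293 cells (Homo sapiens) for cytotoxicity, read by MTT assay; on this read-out lower numbers stand for stronger inhibition and higher numbers for weaker inhibition. In this assay compound 1 gives 100000 nM. In this assay compound 2 gives 100000 nM, level with compound 1 at the digits recorded and within the scatter of it. For compound 3 this assay reports only a limit, > 100000 nM, and not a number. This is the situation described by the limit of > 100000 nM in this assay, at which 1 of the 3 values shown sits.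

Compound 4 differs from compound 2 in a single place: methoxy in place of trifluoromethyl on an aromatic carbon. Within the data shown here, no step between two measured compounds is available in this assay, and the two numbers that do exist sit within the scatter of one another, so no direction can be read from them. For the change at hand the expected step in this assay is no change at the digits printed from compound 2 to compound 4 (within the scatter), that is, nothing beyond the scatter. Compound 4 is accordingly estimated at 100000 nM, with a range from 50000 nM to 200000 nM. It is quite possible that this assay will return only a limit for compound 4 rather than a number.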

Compound 4, half-maximal inhibitory concentration: 100000 nM
The estimate for compound 4 equals the measured number at the digits printed, and the stated range covers the measured number.
By their numbers in this assay, from the lowest: compounds 1, 2 and 4 (each within the scatter of the next).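

In this assay the result is no change at the digits printed from compound 2 to compound 4 (within the scatter) for methoxy in place of trifluoromethyl on an aromatic carbon, para to a large group. Within the data shown here, this is the first step available between two measured compounds that differ in one place, and it shows that at this position a group of 4 heavy atoms with 0 hydrogen-bond acceptors and a group of 2 heavy atoms with 1 hydrogen-bond acceptor read alike. Compound 3 returns only a limit and not a number, and the printed figures of the other compounds stand at the same level, so this step may say little about the change itself: the limit of > 100000 nM in this assay, at which 1 of the 4 values shown sits.

The compounds shown leave open whether any group on this aromatic carbon, such as an amine or a carboxylic acid, would give a number clearly apart from this level. They also leave open whether a change elsewhere on the shared core, such as a longer chain, would bring a reading beyond the scatter of these values.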